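Swapping the Furan Arm for a Methylated Thiophene Arm

This account rests on a few compounds, and the source may have more. Where it says the series, first, only, none or still open, it means among the compounds named here.

Compound 3 `c1cc(CNC2CCN(CCCc3c[nH]c4ccc(-n5cnnc5)cc34)CC2)co1` gives the smallest maximal response of the three compounds measured in a functional assay on CHO cells for activation of 5-hydroxytryptamine receptor 1D (Homo sapiens), read by GTPgammaS binding; on this read-out lower numbers stand for smaller maximal responses and higher numbers for larger maximal responses: compound 3 reaches 65%, whereas compound 1 `c1ccc(CNCC2CCN(CCCc3c[nH]c4ccc(-n5cnnc5)cc34)CC2)cc1` reaches 101% and compound 2 `COC[C@H](NC1CCN(CCCc2c[nH]c3ccc(-n4cnnc4)cc23)CC1)c1ccccc1` reaches 93%. The two steps onto compound 3 were a number 36 percentage points lower from compound 1 to compound 3 (beyond the scatter) and a number 28 percentage points lower from compound 2 to compound 3 (beyond the scatter). Compound 4 `CN(Cc1ccsc1)C1CCN(CCCc2c[nH]c3ccc(-n4cnnc4)cc23)CC1` differs from compound 3 by methyl((thiophen-3-yl)methyl)amino in place of ((furan-3-yl)methyl)amino on a saturated ring carbon. Going by the values given here, no measured step covers the loss of the amine hydrogen or the furan-to-thiophene exchange, so the bearing steps only show that the furan arm sits low. Compound 4 is therefore expected to recover part of that ground, with an estimated step of a number 13 percentage points higher from compound 3 to compound 4 (beyond the scatter) in this assay . Compound 4 is estimated at 78%, within 58% to 98%.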

Compound 4, largest response reached (reported as efficacy), in percent of the reference or control that the assay uses: 93%
The estimate for compound 4 lay 15 percentage points below the measured number; measured number inside the range.
By their numbers in this assay, from the lowest: compound 3; then compounds 2, 4 and 1 (each within the scatter of the next).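

In this assay the methyl((thiophen-3-yl)methyl)amino arm brings a number 28 percentage points higher from compound 3 to compound 4 (beyond the scatter), so the low maximal response of compound 3 does not extend to every arm with a five-membered aromatic ring on this saturated ring carbon. This arm, with 0 hydrogen-bond donors, shows no change at the digits printed from compound 2 to compound 4 (within the scatter) and a number 8 percentage points lower from compound 1 to compound 4 (within the scatter), so a donor in the arm is not required for a response of this size. No evidence is available to explain the step. Methyl and thiophene enter together, so their shares remain open. The ((thiophen-3-yl)methyl)amino and methyl((furan-3-yl)methyl)amino arms would separate them.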